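Three measured analogues, one still to predict

The source may hold more compounds than are shown below. What is called first, only, known or untested is meant among the compounds shown, and "the series" means these compounds.

Four compounds share one core and differ only in the aromatic group attached to an aromatic nitrogen. Compound 1 is `CCOc1ccccc1-n1nncc1CN1C(=O)C2(C(C#N)=C(N)Oc3c2c2nc4ccccc4nc2c2ccccc32)c2ccccc21`, compound 2 is `N#CC1=C(N)Oc2c(c3nc4ccccc4nc3c3ccccc23)C12C(=O)N(Cc1cnnn1-c1ccc(S(N)(=O)=O)cc1)c1ccccc12`, compound 3 is `N#CC1=C(N)Oc2c(c3nc4ccccc4nc3c3ccccc23)C12C(=O)N(Cc1cnnn1-c1cccc(S(N)(=O)=O)c1)c1ccccc12`, and the unmeasured compound 4 is `N#CC1=C(N)Oc2c(c3nc4ccccc4nc3c3ccccc23)C12C(=O)N(Cc1cnnn1-c1ccc(Cl)c(Cl)c1)c1ccccc12`. In a functional assay on HCT-116 cells (Homo sapiens) for antiproliferative activity, read by MTT assay, with a stated time of 48 h (a lower number here means a stronger inhibitor, a higher number a weaker inhibitor), compound 1 reaches only the limit of the assay, > 50000 nM, so no number exists for it (the limit of > 50000 nM in this assay, at which 1 of the 3 values shown sits). In this assay compound 2 gives 31200 nM. In this assay compound 3 gives 11300 nM. Going by the values given here, of the two plain numbers the lowest belongs to compound 3, and the one step separating it from its neighbour is a 2.8-fold lower number from compound 2 to compound 3 (0.44 log units; beyond the scatter).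

The change to compound 4 is 3,4-dichlorophenyl in place of 3-sulfamoylphenyl on an aromatic nitrogen. The measured steps of an at least 1.6-fold lower number from compound 1 to compound 2 (0.20 log units; that floor lies within the scatter), an at least 4.4-fold lower number from compound 1 to compound 3 (0.64 log units; beyond the scatter) and a 2.8-fold lower number from compound 2 to compound 3 (0.44 log units; beyond the scatter) all come from placing or moving a sulfamoyl group on this aromatic ring; none of them introduces chlorine, and the group that enters carries no hydrogen-bond donor or acceptor. They show that changing this aromatic group shifts the result by modest amounts at most, and they give no direction for the present change. For compound 4 in this assay the expected step is therefore small and uncertain, a 1.6-fold higher number from compound 3 to compound 4 (0.20 log units; within the scatter), leaning toward a weaker result. Compound 4 is estimated at 18000 nM, within 4000 nM to 50000 nM.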

Compound 4, half-maximal inhibitory concentration: > 50000 nM
Compound 4: a limit, no number; the forecaster's own chance of this, stated with the estimate: 30%; middle value at least 2.7-fold (0.44 log units) from the limit.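

Compounds 1 and 4 both end at a limit of the assay rather than at a number, so the step between them cannot be read: the limit of > 50000 nM in this assay, at which 2 of the 4 values shown sit.

The new comparisons give an at least 4.4-fold higher number from compound 3 to compound 4 (0.64 log units; beyond the scatter) and an at least 1.6-fold higher number from compound 2 to compound 4 (0.20 log units; that floor lies within the scatter); only the first of these floors clears the scatter, so the loss of activity is firmly shown against compound 3 but not against compound 2. Before this result, 2-ethoxyphenyl was the only group without a sulfamoyl group, whereas now 3,4-dichlorophenyl, with 0 hydrogen-bond donors and 0 hydrogen-bond acceptors, also fails to give a plain number, and among these four compounds only compounds 2 and 3, which carry a sulfamoyl group, give one.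

The compounds shown leave open whether the sulfamoyl group itself is needed on this aromatic ring, or whether another group, such as an amine or a carboxylic acid, could take its place and still give a plain number. They also leave open whether a ring with a single chlorine would behave like the 3,4-dichlorophenyl group of compound 4.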